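Swapping Fluorophenyl for Methylphenyl: an Expected Gain

The compounds below may be only part of what the source reports. "The series", "measured", "known", "first", "only" and "open" are said of these compounds alone.

Compound 1 `Oc1c(C(Nc2ccccn2)c2ccccc2F)ccc2cccnc12` — 470 nM
Compound 2 `Cc1ccnc(NC(c2ccccc2F)c2ccc3cccnc3c2O)c1` — 880 nM
Compound 3 `Cc1ccnc(NC(c2ccccc2)c2ccc3cccnc3c2O)c1` — < 200 nM

In an assay for inhibition of protein disulfide-isomerase (Homo sapiens), with a stated time of 1 h (on this read-out higher numbers stand for weaker inhibition and lower numbers for stronger inhibition), compound 1 gives 470 nM, the lowest of the two numbers shown. Compound 2 gives 880 nM, and the step of a 1.9-fold higher number from compound 1 to compound 2 (0.27 log units; within the scatter) lies within the scatter. For compound 3 the value < 200 nM is a limit of the assay, not a number. Compound 4 `Cc1ccc(C(Nc2ccccn2)c2ccc3cccnc3c2O)cc1` differs from compound 1 by 4-methylphenyl in place of 2-fluorophenyl on a saturated chain carbon bound to an aromatic carbon and a nitrogen on an aromatic ring. Within the data shown here, two measured steps bear on this change: an at least 4.4-fold lower number from compound 2 to compound 3 (0.64 log units; beyond the scatter), and a 1.9-fold higher number from compound 1 to compound 2 (0.27 log units; within the scatter). Removal of fluoro is thus expected to lower the number, while the added methyl is expected to change little, so compound 4 is estimated at 150 nM (range 50 nM to 400 nM), a step of a 3.1-fold lower number from compound 1 to compound 4 (0.50 log units; beyond the scatter). Given (the limit of < 200 nM in this assay, at which 1 of the 3 values shown sits), the result may again be reported only as a limit.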

Compound 4, half-maximal inhibitory concentration: 460 nM
The estimate for compound 4 lay 3.1-fold (0.49 log units) below the measured number, and the stated range ends below it.
By their numbers in this assay, from the lowest: compounds 4, 1 and 2 (each within the scatter of the next). At a limit, below all of these: compound 3.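

On the saturated chain carbon bound to an aromatic carbon and a nitrogen on an aromatic ring, 4-methylphenyl takes the place of 2-fluorophenyl with a 1.0-fold lower number from compound 1 to compound 4 (0.01 log units; within the scatter), so this exchange leaves the number in this assay unmoved. The drop seen in an at least 4.4-fold lower number from compound 2 to compound 3 (0.64 log units; beyond the scatter) does not carry over to this swap, in which fluoro leaves and a methyl enters. The limit remains with compound 3 alone: the limit of < 200 nM in this assay, at which 1 of the 4 values shown sits.

From the compounds shown here alone, what stays open is how much the loss of fluoro and the gain of methyl each count on the core of compound 1. Also open, going by these compounds, is whether a methoxy group or an amine on that ring would shift the number.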